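The source may hold more compounds than are shown below. What is called first, only, known or untested is meant among the compounds shown, and "the series" means these compounds.

Measured compounds:
Compound 1 `COc1ccc(-c2c(C)[nH]c(=O)c3c(N)nn(C)c23)cc1` gives 18% in an assay on isolated protein for inhibition of ribosomal protein S6 kinase alpha-1 (Homo sapiens), read by mobility shift assay, tested at 30 uM; on this read-out lower numbers stand for less inhibition and higher numbers for more inhibition at the one concentration tested (going by the name of the read-out).
Compound 2 `CC(=O)Nc1nn(C)c2cc(-c3ccccc3)[nH]c(=O)c12` gives 4% in this assay.
Compound 3 `Cc1cc2nn(-c3ccccc3)c(N)c2c(=O)[nH]1` gives -11% in this assay.

Among these three numbers, compound 3 stands lowest. The nearest to it is compound 2, whose number lies higher by a gap beyond the usual scatter, and the furthest is compound 1, higher still by a gap that is also beyond the scatter. Compound 3 thus shows no inhibition worth the name in this assay.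

The next compound, compound 4 `COc1ccc(-c2cc3nn(-c4ccccc4)c(N)c3c(=O)[nH]2)cc1`, is compound 3 with one change: 4-methoxyphenyl in place of methyl on an aromatic carbon. The change sits on an aromatic carbon of a six-membered aromatic ring with one nitrogen, part of the fused two-ring system of the shared core.

Among the compounds with values here, no pair of measured compounds differs in one place only, so no measured step guides the size of this change. Compound 1 carries the same 4-methoxyphenyl group on a differently arranged core and gives 18%, which is the highest of the three values, yet its core differs in more than one place from compound 3, so it offers only a loose hint. In this assay a step from compound 3 to compound 4 of a number 16 percentage points higher from compound 3 to compound 4 (beyond the scatter) is expected, a modest rise that may or may not exceed the scatter. Compound 4 is therefore estimated at 5%, within a range from -15% to 30%.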

Compound 4, a percentage reported as inhibition, at one concentration (the size of the read-out at that concentration, not a potency): 4%
For compound 4 the middle estimate is 1 percentage points above the measured one; the measured number falls inside the stated range.
By their numbers in this assay, from the lowest: compound 3; then compounds 2 and 4 (each within the scatter of the next); then compound 1.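

Within the data shown here, putting 4-methoxyphenyl in place of methyl on this aromatic carbon gives the first one-place comparison in this assay, and the outcome is a number 15 percentage points higher from compound 3 to compound 4 (beyond the scatter). This shows that the position accepts a group of 8 heavy atoms with its own six-membered aromatic ring where a single carbon stood before, and that the number still moves upward, yet compound 4 reaches only 4%, which remains weak inhibition at the one concentration tested. No measurement at hand tells whether the added ring, the methoxy oxygen or the sheer size of the new group accounts for this step.

Left open is whether a plain phenyl ring without the methoxy group would give a number close to that of compound 4, and what a smaller or quite different group on the same carbon, such as a carboxylic acid or a dimethylamino group, would do. Also open is whether any group at this position can carry inhibition well beyond this low level, as the compounds shown hold only methyl and 4-methoxyphenyl there on the shared core.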